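Adding a Heptyl Group to Compound 2

The compounds below may be only part of what the source reports. "The series", "measured", "known", "first", "only" and "open" are said of these compounds alone.

In an ADME assay on Vero cells (Chlorocebus sabaeus) for cytotoxicity, read by MTT assay (on this read-out higher numbers stand for weaker inhibition and lower numbers for stronger inhibition), compound 1 `CCCC(C)C(=O)OCC(C)(C)CC1=C(O)C(=O)c2ccccc2C1=O` gives 120 nM, while compound 2 `CCCCCCCCC(=O)OCC(C)(C)CC1=C(O)C(=O)c2ccccc2C1=O` gives 150000 nM. Among the measured compounds shown here, compound 2 therefore holds the higher of the only two numbers measured so far, which on this read-out means the weaker inhibition. Compound 3 `CCCCCCCCCCCCCCCC(=O)OCC(C)(C)CC1=C(O)C(=O)c2ccccc2C1=O` keeps the shared core of compound 2 and differs from it in one place: heptyl in place of hydrogen on a saturated chain carbon, eight bonds along the chain from a carbonyl carbon. In words, heptyl takes the place of hydrogen on a saturated chain carbon, eight bonds along the chain from a carbonyl carbon.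

For the measured compounds named here, only one measured step bears on this change: a 1300-fold higher number from compound 1 to compound 2 (3.10 log units; beyond the scatter). That step is large and beyond the scatter, and it came with octyl in place of 1-methylbutyl on a carbonyl carbon. A single step cannot show a trend, and it says little about what happens when a chain that is already straight grows further. A repeat of so large a rise is therefore not expected, and any move in this assay should be slight and upward. The expected step is a 1.3-fold higher number from compound 2 to compound 3 (0.12 log units; within the scatter), probably not beyond the scatter. For compound 3 the estimated value is 200000 nM, with an expected range from 40000 nM to 1000000 nM.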

Compound 3, half-maximal inhibitory concentration: 4410 nM
Compound 3: middle estimate off by 45-fold (1.66 log units), on the high side; measured number outside the range, below it.
By their numbers in this assay, from the lowest: compound 1; then compound 3; then compound 2.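

Extending the straight chain of compound 2 does not leave the number where it was: in this assay, heptyl in place of hydrogen at this carbon, eight bonds along the chain from a carbonyl carbon, gives a 34-fold lower number from compound 2 to compound 3 (1.53 log units; beyond the scatter), a move towards stronger inhibition. The very high number of compound 2 therefore does not hold for every straight chain at this end of the molecule, and the earlier rise, a 1300-fold higher number from compound 1 to compound 2 (3.10 log units; beyond the scatter), cannot be read as a rule that larger groups here always give higher numbers, since compound 3 goes against such a rule. No measurement shown here accounts for the fall in the number, so the reason for it remains unknown.

Among the compounds shown here, three compounds give only two steps, so they cannot show whether the number falls gradually or abruptly as the chain grows, and a propyl group at the same carbon would help to fill the wide gap between hydrogen and heptyl. As far as these compounds go, it also remains open whether the lower number depends on a purely carbon chain, or would persist if the heptyl group ended in a carboxylic acid or an amine.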